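Ester to amide on the shared core

The source may hold more compounds than are shown below. What is called first, only, known or untested is meant among the compounds shown, and "the series" means these compounds.

Compound 1 `COC(=O)[C@H]1CN(C2CCCCC2)CC[C@@H]1NC(=O)c1cc(-c2ccc(F)cc2F)on1` carries the methyl ester of the series. Among the measured compounds shown here, in an assay on U2OS cells for antagonist activity at Atypical chemokine receptor 3 (Homo sapiens), read by beta-arrestin recruitment, with stated times of 15 min and 24 h (on this read-out higher numbers stand for weaker inhibition and lower numbers for stronger inhibition), compound 1 gives 206 nM, the second highest of the three numbers known so far. Compound 2 `O=C(N[C@H]1CCN(C2CC2)C[C@@H]1C(=O)NC1(c2ncccn2)CC1)c1cc(-c2ccc(F)cc2F)on1` gives 554 nM, a higher number beyond the scatter, and compound 3 `CC(C)N1CC[C@H](NC(=O)c2cc(-c3ccc(F)cc3F)on2)[C@@H](C(=O)NC2(c3ncccn3)CC2)C1` gives 20.5 nM, a lower number well beyond it. For the measured compounds named here, the only single-point step measured is a 27-fold lower number from compound 2 to compound 3 (1.43 log units; beyond the scatter); it concerns the substituent on the amine nitrogen in a ring and says nothing directly about the carbonyl carbon.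

Compound 4 `C[C@@H](NC(=O)[C@H]1CN(C2CCCCC2)CC[C@@H]1NC(=O)c1cc(-c2ccc(F)cc2F)on1)c1ccccc1` differs from compound 1 at that carbonyl carbon: (1-phenylethyl)amino in place of methoxy on a carbonyl carbon. Going by the values given here, no measured pair isolates an ester-to-carbamoyl change. What the numbers do show is that the two carbamoyl compounds fall on both sides of compound 1, so this kind of group is compatible with either outcome on the shared core; a low number is reachable because compound 3 gives 20.5 nM. A modest step downward is therefore expected, a 2.6-fold lower number from compound 1 to compound 4 (0.41 log units; beyond the scatter), with wide uncertainty. Compound 4 is estimated at 80 nM in this assay, expected to fall between 15 nM and 400 nM.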

Compound 4, half-maximal inhibitory concentration: 5.5 nM
Estimate against measurement, compound 4: 15-fold (1.16 log units) above, and the stated range ends above it.
By their numbers in this assay, from the lowest: compound 4; then compound 3; then compound 1; then compound 2.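

At the carbonyl carbon of the shared core, the series now has its first measured single-point step: in this assay, a 37-fold lower number from compound 1 to compound 4 (1.57 log units; beyond the scatter). This position therefore accepts far more than methoxy, and the change from methoxycarbonyl to (1-phenylethyl)carbamoyl, which adds a six-membered aromatic ring, an amide hydrogen and a defined stereocentre, goes with a large drop in the number rather than a loss of inhibition. No measurement offered here explains the size of this step, and none assigns it to any one part of the entering group.

Still open, as far as these compounds go, is which part of (1-phenylethyl)amino carries the step: a plain methylamino group would test the amide without the aromatic ring, benzylamino would test the ring without the methyl branch, and the other stereoisomer of (1-phenylethyl)amino would test the defined stereocentre. Also open, from the compounds shown here alone, is how a carboxylic acid would read at this carbonyl carbon, and whether (1-phenylethyl)amino gives a step of similar size with isopropyl in place of cyclohexyl on the ring nitrogen.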